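A swap at one ring carbon of a nucleoside core

This account rests on a few compounds, and the source may have more. Where it says the series, first, only, none or still open, it means among the compounds named here.

Compound 1 `Cc1nc(N)c2c(-c3ccsc3)cn([C@@H]3O[C@H](CO)[C@@H](O)[C@H]3O)c2n1` and compound 2 `Cc1nc(N)c2c(I)cn([C@@H]3O[C@H](CO)[C@@H](O)[C@H]3O)c2n1` share one core and differ in a single group. In a functional assay on A549 cells (Homo sapiens), read by MTT assay, with a stated time of 72 h (a lower number here means a stronger inhibitor, a higher number a weaker inhibitor), compound 1 gives only a limit, > 20000 nM. In this assay, among the compounds with values here, compound 2, the only compound with a number, gives 12100 nM. The step of an at least 1.6-fold lower number from compound 1 to compound 2 (0.21 log units; that floor lies within the scatter) starts from the limit of > 20000 nM in this assay, at which 1 of the 2 values shown sits. Compound 3 `C#Cc1cn([C@@H]2O[C@H](CO)[C@@H](O)[C@H]2O)c2nc(C)nc(N)c12` is not yet measured and differs from compound 2 by ethynyl in place of iodo on an aromatic carbon. Within the data shown here, no measured step swaps iodo for ethynyl, and the one measured step has a floor within the scatter, so little guidance exists. Compound 3 is expected near 8000 nM, between 2000 nM and 30000 nM. That estimate means a 1.5-fold lower number from compound 2 to compound 3 (0.18 log units; within the scatter).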

Compound 3, half-maximal inhibitory concentration: > 20000 nM
Compound 3 gave a limit, no number (the forecaster's own chance of this, stated with the estimate: 25%); middle value at least 2.5-fold (0.39 log units) from the limit.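

Ethynyl in place of iodo on this aromatic carbon gives an at least 1.6-fold higher number from compound 2 to compound 3 (0.21 log units; that floor lies within the scatter) in this assay. Compound 3 gives only a limit, as compound 1 does, so neither ethynyl nor thiophen-3-yl yields a number here, and the step between those two compounds cannot be read. Iodo remains the only group with a number, and most of the data now sit at one boundary: the limit of > 20000 nM in this assay, at which 2 of the 3 values shown sit.

As far as these compounds go, how far compound 1 and compound 3 lie beyond that limit stays open. So does whether a bromine, a chlorine, an amine or a methyl at this carbon would give a number.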